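The source may report more compounds than this note shows. Statements on the series, on what has been measured and on what is new or still open speak of the compounds shown alone.

Measured in an ADME assay on microsomes from liver (Rattus norvegicus, strain Crj:CD(SD)) for metabolic stability, read by LC-MS, with a stated time of 30 min, tested at 2 uM; on this read-out higher numbers stand for a more stable compound and lower numbers for a less stable compound:
- compound 1 `CC(C)N1CN(C(c2ccccc2)c2ccccc2)n2ccc(=O)c(O)c2C1=O`: 86%
- compound 2 `O=C1c2c(O)c(=O)ccn2N(C(c2ccccc2)c2ccccc2)CN1Cc1ccco1`: 50.6%

Of these two, compound 2 has the lower number, and the gap is beyond the usual scatter. Compound 3 `CN1CN(C(c2ccccc2)c2ccccc2)n2ccc(=O)c(O)c2C1=O` is still unmeasured. It differs from compound 2 by one change, hydrogen in place of furan-2-yl on a saturated chain carbon bound to an amide-type nitrogen in a ring, which turns (furan-2-yl)methyl into methyl. For the measured compounds named here, only one measured step bears on this: a number 35.4 percentage points lower from compound 1 to compound 2 (beyond the scatter), a large step beyond the scatter, with (furan-2-yl)methyl in place of isopropyl. Methyl is not isopropyl, and no measured compound carries methyl there. Still, the furan-2-yl is gone, so a rise from compound 2 at 50.6% towards compound 1 at 86% is expected in this assay. The expected step is a number 24.4 percentage points higher from compound 2 to compound 3 (beyond the scatter). For compound 3 the estimate is 75%, with an expected range of 60% to 90%.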

Compound 3, percent of the compound remaining: 92.1%
Estimate against measurement, compound 3: 17.1 percentage points below, outside the stated range (above it).
By their numbers in this assay, from the lowest: compound 2; then compounds 1 and 3 (each within the scatter of the next).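

In this assay, shortening (furan-2-yl)methyl to methyl on the amide-type nitrogen in a ring gives a number 41.5 percentage points higher from compound 2 to compound 3 (beyond the scatter), so the low number of compound 2 now stands out against a second partner rather than only against the isopropyl compound. Methyl in place of isopropyl at this position gives a number 6.1 percentage points higher from compound 1 to compound 3 (within the scatter), and these two groups cannot be told apart in this read-out. Among these three compounds, therefore, only (furan-2-yl)methyl separates from the others at this position.

As far as these compounds go, whether the furan ring itself matters, or any ring on that chain would do the same, stays open; benzyl, or a longer chain such as n-butyl, would help separate these readings. No measured information explains the difference in stability.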